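The compounds below may be only part of what the source reports. "The series", "measured", "known", "first", "only" and "open" are said of these compounds alone.

Compound 1 `COc1ccc(S(=O)(=O)c2cnc3ccc(C)cc3c2N2CCC(C)CC2)cc1`: 62%
Compound 2 `Cc1cc(C)cc(S(=O)(=O)c2cnc3ccc(C)cc3c2N2CCC(C)CC2)c1`: 80%
Compound 3 `Cc1cc(C)cc(S(=O)(=O)c2cnc3ccc(F)cc3c2N2CCC(C)CC2)c1`: 83%

In an assay on isolated protein for displacement of a labelled ligand from metabotropic glutamate receptor 5 (Homo sapiens), with a stated time of 60 min, tested at 1 uM (on this read-out higher numbers stand for more inhibition at the one concentration tested (going by the name of the read-out) and lower numbers for less inhibition), compound 2 stands second highest of the three, with compound 3 within the scatter of it (a number 3 percentage points higher from compound 2 to compound 3 (within the scatter)) and compound 1 well below it (a number 18 percentage points higher from compound 1 to compound 2 (beyond the scatter)). Compound 4 `Cc1ccc2ncc(S(=O)(=O)c3cccc(F)c3)c(N3CCC(C)CC3)c2c1` differs from compound 2 in one place: 3-fluorophenyl in place of 3,5-dimethylphenyl on a sulfonyl sulfur. For the measured compounds named here, two measured steps bear on this. Going by the values given here, the only other change at the sulfonyl sulfur, a number 18 percentage points higher from compound 1 to compound 2 (beyond the scatter), was modest and beyond the scatter, showing that the group on that sulfur matters. The change a number 3 percentage points higher from compound 2 to compound 3 (within the scatter), where fluoro replaced methyl on an aromatic carbon, stayed within the scatter. Compound 4 is therefore expected to sit a little below compound 2, with a number 10 percentage points lower from compound 2 to compound 4 (within the scatter) as the estimated step. For compound 4 the estimate is 70%, ranging from 55% to 85%.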

Compound 4, a percentage reported as inhibition, at one concentration (the size of the read-out at that concentration, not a potency): 94%
The estimate for compound 4 lay 24 percentage points below the measured number; the measured number lies above the stated range.
By their numbers in this assay, from the lowest: compound 1; then compounds 2 and 3 (each within the scatter of the next); then compound 4.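

In this assay, the group on the sulfonyl sulfur still had room to raise the number beyond what 3,5-dimethylphenyl gave: 3-fluorophenyl produced a number 14 percentage points higher from compound 2 to compound 4 (beyond the scatter) and a number 32 percentage points higher from compound 1 to compound 4 (beyond the scatter). The entering group has fewer heavy atoms and no methyl, so neither methyl of 3,5-dimethylphenyl was needed for this read-out. Nothing available explains why this change raised the number. The compounds shown leave open what an amine or a carboxylic acid on that aromatic ring would do. A single-concentration percentage also leaves the potency of compound 4 open.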